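A Trifluoromethyl Swap Near the Assay Limit

The compounds below may be only part of what the source reports. "The series", "measured", "known", "first", "only" and "open" are said of these compounds alone.

Compound 1 `COc1ccccc1-n1cc(COC(=O)/C(C)=C/CC/C(C)=C/CC/C(C)=C/CC[C@@H]2[C@@]3(C)CCC(=O)C(C)(C)[C@H]3CC[C@@]2(C)O)nn1`, compound 2 `COc1ccc(-n2cc(COC(=O)/C(C)=C/CC/C(C)=C/CC/C(C)=C/CC[C@@H]3[C@@]4(C)CCC(=O)C(C)(C)[C@H]4CC[C@@]3(C)O)nn2)cc1` and compound 3 `C/C(=C\CC/C(C)=C/CC[C@@H]1[C@@]2(C)CCC(=O)C(C)(C)[C@H]2CC[C@@]1(C)O)CC/C=C(\C)C(=O)OCc1cn(-c2ccc(C)cc2)nn1` share one core and differ only in the group on an aromatic nitrogen. In a functional assay on DU-145 cells (Homo sapiens) for antiproliferative activity, read by MTT assay, with a stated time of 48 h (on this read-out lower numbers stand for stronger inhibition and higher numbers for weaker inhibition), compound 1 gives > 150000 nM, which is a limit of the assay and not a number. Compound 2 gives 135000 nM. Compound 3 gives > 150000 nM, which is again a limit. Compound 3 therefore stands at the limit of > 150000 nM in this assay, at which 2 of the 3 values shown sit.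

Compound 4 `C/C(=C\CC/C(C)=C/CC[C@@H]1[C@@]2(C)CCC(=O)C(C)(C)[C@H]2CC[C@@]1(C)O)CC/C=C(\C)C(=O)OCc1cn(-c2cccc(C(F)(F)F)c2)nn1` changes that same group, with 3-(trifluoromethyl)phenyl in place of 4-methylphenyl on an aromatic nitrogen. The measured steps at this position are an at least 1.1-fold lower number from compound 1 to compound 2 (0.04 log units; that floor lies within the scatter), an at least 1.1-fold higher number from compound 2 to compound 3 (0.04 log units; that floor lies within the scatter) and a step that the two limits leave unreadable from compound 1 to compound 3. None of them shows a change beyond the scatter, so no step beyond the scatter is expected in this assay, and no direction can be favoured. The expected result is an at least 1.0-fold lower number from compound 3 to compound 4 (0.02 log units; that floor lies within the scatter). The assay may well report only a limit again. Compound 4 is estimated at 140000 nM, with an expected range from 70000 nM to 220000 nM.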

Compound 4, half-maximal inhibitory concentration: > 150000 nM
Compound 4 gave a limit, no number; the forecaster's own chance of this, stated with the estimate: 55%; middle value at least 1.0-fold (0.02 log units) away from the limit.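

In this assay compound 4 also gives a limit and not a number, so 3-(trifluoromethyl)phenyl adds one more group to those that leave this read-out at its edge: the limit of > 150000 nM in this assay, at which 3 of the 4 values shown sit.

Among the compounds shown here, the only step to compound 4 with a readable size is an at least 1.1-fold higher number from compound 2 to compound 4 (0.04 log units; that floor lies within the scatter), so even a swap to a group with fluorine shows no change beyond the scatter at this position. The steps to compound 4 from compound 1 and from compound 3 cannot be read, as both ends of each are limits.

All four groups shown are substituted phenyl rings; whether a carboxylic acid or an amine on that ring would give a clearly lower number remains open. The three compounds at the limit also cannot be ranked against one another.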